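The source may report more compounds than this note shows. Statements on the series, on what has been measured and on what is new or still open speak of the compounds shown alone.

Working notes on the series. In a functional assay on B16-F0 cells (Mus musculus) for inhibition, read by CCK-8 assay, with a stated time of 48 h (on this read-out lower numbers stand for stronger inhibition and higher numbers for weaker inhibition), compound 2 `COc1cc(-c2ccnc3cc(-c4ccc(C(C)=O)cc4)nn23)cc(OC)c1OC` gives 3930 nM and so stands lowest of the two numbers recorded, yet compound 1 `Cn1ccc2cc(-c3cc4nccc(-c5ccc(F)cc5)n4n3)ccc21` gives 4780 nM, a gap within the scatter, so no order between them is claimed. Compound 3 `COc1cc(-c2cc3nccc(-c4c[nH]c5ccccc45)n3n2)cc(OC)c1OC` returns only a limit of the assay, > 10000 nM. Compound 4 `COc1ccc(-c2cc3nccc(-c4cc(OC)c(OC)c(OC)c4)n3n2)cc1` is compound 2 carrying (methoxy in place of acetyl on an aromatic carbon). Among the compounds with values here, no step between measured compounds shares this change, so its size is open. For compound 4 the expected step is a 1.4-fold higher number from compound 2 to compound 4 (0.15 log units; within the scatter), a small weakening if any, not clearly beyond the scatter in this assay. Compound 4 is accordingly estimated at 5500 nM, with a range from 2000 nM to 15000 nM.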

Compound 4, half-maximal inhibitory concentration: 1410 nM
The estimate for compound 4 lay 3.9-fold (0.59 log units) above the measured number; the measured number lies below the stated range.
By their numbers in this assay, from the lowest: compound 4; then compounds 2 and 1 (each within the scatter of the next). At a limit, above all of these: compound 3.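

In this assay, within the data shown here, the change from 4-acetylphenyl to 4-methoxyphenyl gives a 2.8-fold lower number from compound 2 to compound 4 (0.45 log units; beyond the scatter) and is the first step readable. This place, para to a large group, therefore responds to the change by more than the scatter, and the acetyl is not required for the number seen with compound 2. No measurement shown bears on why the step occurs.

Going by these compounds, whether an amine or a carboxylic acid at this place would lower or raise the number remains open. So does whether the step holds on a different shared core.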